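The source may hold more compounds than are shown below. What is called first, only, known or untested is meant among the compounds shown, and "the series" means these compounds.

Compound 1 `CCCCC/C=C/C=C/C=N/Nc1nc(N)c2ncn([C@@H]3O[C@H](CO)[C@@H](O)[C@H]3O)c2n1` gives 2 nM in an assay on CHO-K1 cells for displacement of a labelled ligand from adenosine receptor A1 (Homo sapiens), read by scintillation counting, with a stated time of 60 min; a higher number here means a weaker inhibitor, a lower number a stronger inhibitor. Compound 2 `CCOc1cc(/C=N/Nc2nc(N)c3ncn([C@@H]4O[C@H](CO)[C@@H](O)[C@H]4O)c3n2)ccc1O` gives 6940 nM in this assay, and the step of a 3500-fold higher number from compound 1 to compound 2 (3.54 log units; beyond the scatter) is large. Compound 3 `CSCC/C=N/Nc1nc(N)c2ncn([C@@H]3O[C@H](CO)[C@@H](O)[C@H]3O)c2n1` reaches only the limit > 10000 nM in this assay, a limit of the measurement (the limit of > 10000 nM in this assay, at which 1 of the 3 values shown sits). The step of an at least 5000-fold higher number from compound 1 to compound 3 (3.69 log units; beyond the scatter) is large, while an at least 1.4-fold higher number from compound 2 to compound 3 (0.15 log units; that floor lies within the scatter) has a floor within the scatter, so compound 3 stands far from compound 1. Compound 4 `Nc1nc(N/N=C/c2ccc(N3CCCC3)cc2)nc2c1ncn2[C@@H]1O[C@H](CO)[C@@H](O)[C@H]1O` differs from compound 3 by 4-(pyrrolidin-1-yl)phenyl in place of 2-(methylsulfanyl)ethyl on a carbon with a double bond to nitrogen. Compound 2, which also carries an aromatic ring on the carbon with a double bond to nitrogen, gives 6940 nM, so compound 4 is expected to land in that region, with an estimated step of an at least 3.3-fold lower number from compound 3 to compound 4 (0.52 log units; beyond the scatter). Compound 4 is therefore estimated at 3000 nM, between 500 nM and 20000 nM.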

Compound 4, inhibition constant: 5.1 nM
Beside the measured number, compound 4's estimate is 590-fold (2.77 log units) above it; measured number outside the range, below it.
By their numbers in this assay, from the lowest: compound 1; then compound 4; then compound 2. At a limit, above all of these: compound 3.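

Here an aromatic ring on the carbon with a double bond to nitrogen goes with a low number in this assay: 4-(pyrrolidin-1-yl)phenyl in place of 3-ethoxy-4-hydroxyphenyl brings a 1400-fold lower number from compound 2 to compound 4 (3.13 log units; beyond the scatter). The same group in place of 2-(methylsulfanyl)ethyl brings an at least 1900-fold lower number from compound 3 to compound 4 (3.29 log units; beyond the scatter), and the open chain of compound 1 no longer stands alone at the low end, with a 2.6-fold higher number from compound 1 to compound 4 (0.41 log units; beyond the scatter). That step from compound 3 is only a floor, as compound 3 stands at a limit: the limit of > 10000 nM in this assay, at which 1 of the 4 values shown sits.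

From the compounds shown here alone, whether a dimethylamino or morpholin-4-yl group on the phenyl, or a bare phenyl, would give a number like that of compound 4 stays open.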